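The compounds below may be only part of what the source reports. "The series", "measured", "known", "first", "only" and "open" are said of these compounds alone.

Compound 1 `COc1cc(-c2cc(/C=C/C(=O)c3ccc(N)cc3)[nH]n2)cc(OC)c1OC` and compound 2 `COc1ccc(-c2cc(/C=C/C(=O)c3ccc(N)cc3)[nH]n2)cc1OC` share one core, and compound 2 differs from compound 1 by hydrogen in place of methoxy on an aromatic carbon. In a functional assay on UACC-257 cells (Homo sapiens) for cytotoxicity, read by sulforhodamine B assay, with a stated time of 48 h, tested at 10 uM (a higher number here means a weaker effect of the compound at the concentration tested, a lower number a stronger effect), compound 1 gives -59%, while compound 2 gives 39%. The step is a number 98 percentage points higher from compound 1 to compound 2 (beyond the scatter). Compound 3 `COc1cc(C(=O)/C=C/c2cc(-c3cc(OC)c(OC)c(OC)c3)n[nH]2)cc(OC)c1OC` is built on a different core, and the difference between the two cores is not broken down here. In this assay compound 3 gives -93%, the lowest of the three numbers. Compound 4 `COc1ccc(-c2cc(/C=C/C(=O)c3cc(OC)c(OC)c(OC)c3)[nH]n2)cc1OC` has not yet been measured in this assay. Among the measured compounds shown here, compound 4 differs from compound 3 by hydrogen in place of methoxy on an aromatic carbon, the same change as the one between compound 1 and compound 2, with the same surroundings at the place of change. The step is expected to be about as large as before, namely a number 93 percentage points higher from compound 3 to compound 4 (beyond the scatter), because a number 98 percentage points higher from compound 1 to compound 2 (beyond the scatter) was seen on the other core. On this basis compound 4 is expected to show about 0% in this assay, with a range from -50% to 40%, since a single earlier step need not carry over exactly to a new core.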

Compound 4, a percentage reported as activity, at one concentration (the size of the read-out at that concentration, not a potency): -64%
Compound 4: middle estimate off by 64 percentage points, on the high side, and the stated range ends above it.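

In this assay hydrogen in place of methoxy gives a number 29 percentage points higher from compound 3 to compound 4 (beyond the scatter) and so moves the number the same way as on the core of compound 1, which means that the direction of the step carries over between these two cores. The size of the step does not carry over, and the earlier step alone therefore gives a poor measure of the step on the other core: the same change on two cores in this assay, a number 98 percentage points higher (beyond the scatter) from compound 1 to compound 2 and a number 29 percentage points higher (beyond the scatter) from compound 3 to compound 4, 69 percentage points apart, beyond the scatter of two such steps. These two pairs show neither why the steps differ in size nor how the change would behave on any further core, and two cores are too few to support a general rule for the series.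

The compounds shown leave open how a hydroxyl group, a fluorine atom or an ethoxy group would read in this assay at this place on the ring. They also leave open whether replacing a methoxy group at another place on the ring would give a step of similar size.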